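The source may hold more compounds than are shown below. What is called first, only, known or untested is meant among the compounds shown, and "the series" means these compounds.

Compound 1 `O=S(=O)(Nc1ccc2oc(-c3ccccc3)nc2c1)c1ccc(Cl)c(Cl)c1` carries a 3,4-dichlorophenyl group on its sulfonyl sulfur. In an assay on isolated protein for inhibition of malate dehydrogenase, mitochondrial (Sus scrofa), with stated times of 45 min and 30 min (on this read-out lower numbers stand for stronger inhibition and higher numbers for weaker inhibition), compound 1 returns only the limit of the assay, > 63000 nM. Compound 3 `O=S(=O)(Nc1ccc2oc(-c3ccccc3)nc2c1)c1ccc(Cl)c(C(F)(F)F)c1` likewise gives only the limit, > 63000 nM. Compound 2 `O=S(=O)(Nc1ccc(-c2nc3ccccc3o2)cc1)c1ccccc1C(F)(F)F` also stops at the limit, > 63000 nM. Between compounds 1 and 3 the data show a step that the two limits leave unreadable from compound 1 to compound 3, and the whole of the evidence is the limit of > 63000 nM in this assay, at which 3 of the 3 values shown sit. Compound 4 `O=S(=O)(Nc1ccc2oc(-c3ccccc3)nc2c1)c1ccccc1F` differs from compound 1 by 2-fluorophenyl in place of 3,4-dichlorophenyl on a sulfonyl sulfur. For the measured compounds named here, no measured step bears on this change, and no compound has yet given a number rather than a limit. Compound 4 is therefore expected at 80000 nM, within 30000 nM to 300000 nM, with an expected step that the limit leaves unreadable from compound 1 to compound 4 that is not expected to exceed the scatter.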

Compound 4, half-maximal inhibitory concentration: > 63000 nM
Compound 4 ended at the assay's limit; the forecaster's own chance of this, stated with the estimate: 85%; the middle value is on the limit's open side.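

Compound 1 and compound 4 both stop at the assay's limit, so no step can be read between them: the limit of > 63000 nM in this assay, at which 4 of the 4 values shown sit.

The compounds shown leave open what any of these changes does to inhibition in this assay.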